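Swapping a bromophenyl for a fluorobenzyl on sulfur

This account rests on a few compounds, and the source may have more. Where it says the series, first, only, none or still open, it means among the compounds named here.

compound 1 `O=C(/C(=C\c1ccc(Br)cc1)Sc1ccc(Br)cc1)c1ccc(Br)cc1`: 1000 nM
compound 2 `O=C(/C(=C\c1ccc(F)cc1F)Sc1ccc(Br)cc1)c1ccc(Br)cc1`: 1000 nM

Both compounds were tested in a functional assay on DU-145 cells (Homo sapiens) for inhibition, read by trypan blue exclusion, with a stated time of 96 h; a lower number here means a stronger inhibitor of growth, a higher number a weaker inhibitor of growth. Among the measured compounds shown here, compound 1 gives 1000 nM and compound 2 gives 1000 nM, so compound 1 stands level with compound 2 within the scatter; the single measured step, no change at the digits printed from compound 1 to compound 2 (within the scatter), alters a group on a double-bonded chain carbon, not on the sulfur. Compound 3 `O=C(/C(=C\c1ccc(Br)cc1)SCc1ccc(F)cc1)c1ccc(Br)cc1` differs from compound 1 on a sulfur: 4-fluorobenzyl in place of 4-bromophenyl on a sulfur. For the measured compounds named here, no measured step touches that place, so nothing points in either direction; a step of no size beyond the scatter is expected, no change at the digits printed from compound 1 to compound 3 (within the scatter). Compound 3 is therefore estimated at 1000 nM, expected between 350 nM and 3000 nM.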

Compound 3, concentration for 50% growth inhibition: 25000 nM
Compound 3: middle estimate off by 25-fold (1.40 log units), on the low side; the measured number lies above the stated range.
By their numbers in this assay, from the lowest: compounds 1 and 2 (each within the scatter of the next); then compound 3.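

In this assay, the sulfur proves a sensitive place: putting 4-fluorobenzyl in place of 4-bromophenyl there gives a 25-fold higher number from compound 1 to compound 3 (1.40 log units; beyond the scatter), meaning a much weaker inhibitor of growth. The change on the double-bonded chain carbon gave no such shift (no change at the digits printed from compound 1 to compound 2 (within the scatter)), so the two places respond differently in these compounds. No measurement given here explains the rise.

This change alters both the ring's halogen and the link to sulfur, and the compounds shown cannot separate the two. As far as these compounds go, how 4-bromobenzyl, 4-fluorophenyl or an amine-bearing chain on the sulfur would behave remains open.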